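A Shorter Side Chain on the Sulfonamide Ether

A few compounds are considered here, and "the series" means these few. Any claim that something is new, unique, unknown or untested is made for them only; others in the source may bear on it.

Compound 1 `CC(=O)SCC(=O)c1ccc(NS(=O)(=O)c2ccc(OCc3ccccn3)cc2)nc1` carries a pyridinylmethyl group on the aryl ether oxygen, but in a functional assay on U226 cells (Homo sapiens) for cytotoxicity (a higher number here means that more compound is needed for the effect, a lower number that less compound is needed), compound 1 stands only as "not determined" (no result reported). Going by the values given here, compound 2 `CC(=O)SCC(=O)c1ccc(NS(=O)(=O)c2ccc(OCCCN3CCCCC3)cc2)nc1`, with a 3-(piperidin-1-yl)propyl group in the same position, is the only compound with a number: in this assay compound 2 gives 800 nM, so there is nothing else to rank it against. Compound 3 `CC(=O)SCC(=O)c1ccc(NS(=O)(=O)c2ccc(OC3CCN(C)CC3)cc2)nc1` differs from compound 2 in one place: 1-methylpiperidin-4-yl in place of 3-(piperidin-1-yl)propyl on an oxygen on an aromatic ring. Among the compounds with values here, both groups contain one six-membered non-aromatic ring with a single nitrogen and one hydrogen-bond acceptor, and no step between measured compounds is available to guide the direction. The change from compound 2 to compound 3 is therefore expected to stay within the scatter, with a 1.3-fold higher number from compound 2 to compound 3 (0.10 log units; within the scatter). Compound 3 is estimated to give 1000 nM, with a likely range from 300 nM to 3500 nM.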

Compound 3, half-maximal effective concentration: 300 nM
Estimate against measurement, compound 3: 3.3-fold (0.52 log units) above; measured number inside the range.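

In this assay, replacing 3-(piperidin-1-yl)propyl with 1-methylpiperidin-4-yl gives a 2.7-fold lower number from compound 2 to compound 3 (0.43 log units; beyond the scatter), so less compound is needed for the effect. This shows that the group on this oxygen can change the result, something a single number could not show. The change is also not one of ring or acceptor count: both groups have one six-membered non-aromatic ring with 1 hetero atom and 1 hydrogen-bond acceptor, while the entering group has 7 heavy atoms rather than 9. No measurement on hand accounts for the drop.

This single step cannot separate the loss of the propyl chain from the move to a ring carrying a methyl group on its nitrogen. A 2-(piperidin-1-yl)ethyl chain or a morpholine ring on the same oxygen would be needed to tell how far the trend extends.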